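This account rests on a few compounds, and the source may have more. Where it says the series, first, only, none or still open, it means among the compounds named here.

Working notes on the series in an assay on isolated protein for inhibition of Leucine-rich repeat serine/threonine-protein kinase 2 variant G2019S (Homo sapiens), read by TR-FRET and LanthaScreen, with stated times of 50 min and 30 min, in the presence of a further agent that is not named here; a lower number here means a stronger inhibitor, a higher number a weaker inhibitor. Compound 1 `Cc1nn(CC2(O)COC2)cc1Nc1nc(N)c2c(C#N)c(N3CCC[C@H]3C)n(C)c2n1` gives 51 nM. Compound 2 `Cc1c(Nc2nc(N)c3c(C#N)c(N4CCC[C@H]4C)n(C)c3n2)cnn1CC(C)(C)O` gives 35 nM, and compound 3 `Cn1c(-c2cccc(F)c2F)c(C#N)c2c(N)ncnc21` gives 159 nM. Compound 1 stands second highest of the three numbers: compound 2 lies within the scatter of it, while the gap to compound 3 is beyond the scatter, compound 3 being the higher number. Compound 4 `Cc1n[nH]cc1Nc1nc(N)c2c(C#N)c(N3CCC[C@H]3C)n(C)c2n1` is not yet measured in this assay. It differs from compound 1 in one place: hydrogen in place of (3-hydroxyoxetan-3-yl)methyl on an aromatic nitrogen. Within the data shown here, no pair of measured compounds isolates this change; compounds 1 and 2, which carry different groups on an aromatic nitrogen, lie within the scatter of each other. The step of a 1.2-fold higher number from compound 1 to compound 4 (0.07 log units; within the scatter) is expected to be none beyond the scatter. Compound 4 is estimated at 60 nM, between 20 nM and 180 nM.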

Compound 4, half-maximal inhibitory concentration: 27 nM
Compound 4: middle estimate off by 2.2-fold (0.35 log units), on the high side; low and high end bracket the measured number.
By their numbers in this assay, from the lowest: compounds 4, 2 and 1 (each within the scatter of the next); then compound 3.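

In this assay, hydrogen in place of (3-hydroxyoxetan-3-yl)methyl on the aromatic nitrogen gives a 1.9-fold lower number from compound 1 to compound 4 (0.28 log units; within the scatter) and so removes the whole group, four-membered ring included, without a step beyond the scatter. On this position of the shared core, the group is therefore not required for a number in this range. Nothing measured here explains this result.

Still open, on these data alone, is whether an amine or a carboxylic acid on this nitrogen would stay within the scatter of compound 4. A longer chain ending in a hydroxyl group is equally untested by the compounds shown.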